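Carboxy for Methoxy: Expected Cytotoxicity of Compound 3

A few compounds are considered here, and "the series" means these few. Any claim that something is new, unique, unknown or untested is made for them only; others in the source may bear on it.

Measured compounds:
compound 1, `COc1ccc(Cn2ccc3nc(-c4ccccc4)nc-3c2)cc1`, in an ADME assay on MDBK cells (Bos taurus) for cytotoxicity (on this read-out lower numbers stand for higher toxicity in this test and higher numbers for lower toxicity in this test), gives > 100000 nM, which is a limit of the assay rather than a number.
compound 2, `Clc1ccc(Cn2ccc3nc(-c4ccccc4)nc-3c2)cc1Cl`, gives 71000 nM.

Compound 1 therefore sits at the limit (the limit of > 100000 nM in this assay, at which 1 of the 2 values shown sits), so only a range is known for it. Among the measured compounds shown here, the sole measured step, an at least 1.4-fold lower number from compound 1 to compound 2 (0.14 log units; that floor lies within the scatter), lies within the scatter and concerns a different change. Compound 3, `O=C(O)c1ccc(Cn2ccc3nc(-c4ccccc4)nc-3c2)cc1`, differs from compound 1 by carboxy in place of methoxy on an aromatic carbon. For the measured compounds named here, no measured step bears on this change, so no shift beyond the scatter is expected. Compound 3 is estimated at 100000 nM, between 50000 nM and 200000 nM. The expected step is a number no higher from compound 1 to compound 3 (the limit leaves the size open).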

Compound 3, half-maximal cytotoxic concentration: > 100000 nM
Compound 3 gave a limit, no number; the forecaster's own chance of this, stated with the estimate: 60%; the middle value sits exactly at the limit.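

Compound 1 and compound 3 both give a limit rather than a number, so no step between them can be read: the limit of > 100000 nM in this assay, at which 2 of the 3 values shown sit.

On these data alone, whether carboxy in place of methoxy changes the read-out in this assay at all stays open.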